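The compounds below may be only part of what the source reports. "The series", "measured", "known", "first", "only" and "open" are said of these compounds alone.

Measured set:
Compound 1 `Cc1nc(-c2ccc(F)cc2)oc1-c1csc(Cc2ccccc2)n1` — in an ADME assay on PANC-1 cells (Homo sapiens) for inhibition, read by MTT assay (on this read-out higher numbers stand for weaker inhibition of growth and lower numbers for stronger inhibition of growth), compound 1 gives > 250 ug/mL, a limit of the assay.
Compound 2 `Cc1nc(-c2ccc(F)cc2)oc1-c1csc(Cc2cccc(Cl)c2)n1` — in this assay compound 2 gives > 250 ug/mL, a limit of the assay.
Compound 3 `Cc1nc(-c2ccccc2)oc1-c1csc(-c2ccccc2)n1` — in this assay compound 3 gives > 250 ug/mL, a limit of the assay.

Compound 3 thus stands only at a limit, and the two other values are limits as well, all sitting at the limit of > 250 ug/mL in this assay, at which 3 of the 3 values shown sit. Compound 4 `Cc1nc(-c2ccccc2)oc1-c1csc(Cc2cccc(Cl)c2)n1` carries 3-chlorobenzyl in place of phenyl on an aromatic carbon. Within the data shown here, the one measured step that bears on this change is a step that the two limits leave unreadable from compound 1 to compound 2, whose size cannot be read. Among the measured compounds shown here, no measured step separates phenyl from benzyl on this carbon. With every value at the limit, no step beyond the scatter is expected in this assay in either direction. Compound 4 is therefore expected to show 300 ug/mL, estimated between 120 ug/mL and 1000 ug/mL, most probably once more a limit, and the expected step that the limit leaves unreadable from compound 3 to compound 4 reflects that.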

Compound 4, concentration for 50% growth inhibition: > 250 ug/mL
Compound 4 ended at the assay's limit (the forecaster's own chance of this, stated with the estimate: 85%); the middle value does not contradict the limit.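

The steps from compound 3 to compound 4 and from compound 2 to compound 4 cannot be read, and compound 4 adds only another limit: the limit of > 250 ug/mL in this assay, at which 4 of the 4 values shown sit. The compounds shown leave open how phenyl and 3-chlorobenzyl compare on this carbon in this assay once values fall inside the assay's range.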